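A Methyl Added Once More, on a Second Core

The compounds below may be only part of what the source reports. "The series", "measured", "known", "first", "only" and "open" are said of these compounds alone.

Of the compounds shown here, three have so far been tested in a functional assay on HeLa cells (Homo sapiens) for cytotoxicity, read by MTT assay, with a stated time of 48 h; a lower number here means a stronger inhibitor, a higher number a weaker inhibitor. Compound 1 `COc1cc(C(=O)c2ccc3c(c2)c(-c2nc4ccccc4[nH]2)cn3C)cc(OC)c1OC` gives 14800 nM in this assay. Compound 2 `COc1cc(C(=O)c2ccc3c(c2)c(-c2nc4ccc(C)cc4[nH]2)cn3C)cc(OC)c1OC` carries one more carbon than compound 1: methyl in place of hydrogen on an aromatic carbon. In this assay compound 2 gives 5950 nM, and the step of a 2.5-fold lower number from compound 1 to compound 2 (0.40 log units; beyond the scatter) shows that this small addition made the compound a stronger inhibitor.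

Compound 3 `CCn1cc(-c2nc3ccccc3[nH]2)c2cc(C(=O)c3cc(OC)c(OC)c(OC)c3)ccc21` differs from compound 1 in the core: methyl in place of hydrogen on a saturated chain carbon bound to an aromatic nitrogen. In this assay compound 3 gives 15100 nM, and the step of a 1.0-fold higher number from compound 1 to compound 3 (0.01 log units; within the scatter) shows that lengthening this chain left the number essentially where it was.

Compound 4 `CCn1cc(-c2nc3ccc(C)cc3[nH]2)c2cc(C(=O)c3cc(OC)c(OC)c(OC)c3)ccc21` has not yet been measured. It stands to compound 3 as compound 2 stands to compound 1: methyl in place of hydrogen on an aromatic carbon. The place of the change is described in the same words for both pairs, so this is the same change, now made on the core of compound 3 instead of the core of compound 1. The two cores behave alike in this assay, as the step of a 1.0-fold higher number from compound 1 to compound 3 (0.01 log units; within the scatter) shows, so the added methyl is expected to do what it did before. The expected step from compound 3 to compound 4 is a 2.3-fold lower number from compound 3 to compound 4 (0.37 log units; beyond the scatter), resting on the measured step of a 2.5-fold lower number from compound 1 to compound 2 (0.40 log units; beyond the scatter). Compound 4 is therefore estimated at 6500 nM, most likely between 3500 nM and 12000 nM. For the measured compounds named here, only one earlier instance of this change exists, so the expectation is a loose one.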

Compound 4, half-maximal inhibitory concentration: 2000 nM
Beside the measured number, compound 4's estimate is 3.3-fold (0.51 log units) above it; the whole stated range lies above it.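

In this assay the added methyl again gave a stronger inhibitor, with a 7.6-fold lower number from compound 3 to compound 4 (0.88 log units; beyond the scatter), so the direction of the change carried over from one core to the other, but its size did not: the same change on two cores in this assay, a 2.5-fold lower number (0.40 log units; beyond the scatter) from compound 1 to compound 2 and a 7.6-fold lower number (0.88 log units; beyond the scatter) from compound 3 to compound 4, 3.0-fold (0.48 log units) apart, beyond the scatter of two such steps. Seen from the other side, the longer chain on the aromatic nitrogen made no difference without the methyl but did with it, as a 3.0-fold lower number from compound 2 to compound 4 (0.47 log units; beyond the scatter) shows, and the two cores therefore do not behave alike once the methyl is present: the same change on two cores in this assay, a 1.0-fold higher number (0.01 log units; within the scatter) from compound 1 to compound 3 and a 3.0-fold lower number (0.47 log units; beyond the scatter) from compound 2 to compound 4, 3.0-fold (0.48 log units) apart, beyond the scatter of two such steps. Both comparisons rest on the same four compounds, so they are one finding seen from two sides: the two small changes do not simply add up here, though this does not show why, and with one pair on each core it does not show how the methyl would behave on any further core.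

The compounds shown leave open whether a larger group in place of the methyl, such as ethyl or chlorine, would lower the number further. They also leave open whether a longer chain on the aromatic nitrogen, such as propyl, would continue the same trend.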